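The source may report more compounds than this note shows. Statements on the series, on what has been measured and on what is new or still open speak of the compounds shown alone.

The study opens with compound 1 `O=C(c1cc(-n2cc(-c3ccccc3)nn2)ccc1O)N1CCCCC1`. In a functional assay on RAW264.7 cells (Mus musculus) for inhibition, read by Griess assay, with a stated time of 20 h (on this read-out lower numbers stand for stronger inhibition and higher numbers for weaker inhibition), compound 1 gives only a limit of the assay, > 20000 nM. Compound 2 `CCCCCc1ccc(-c2cn(-c3ccc(O)c(C(=O)N4CCCCC4)c3)nn2)cc1` differs from compound 1 by a single change (pentyl in place of hydrogen on an aromatic carbon). In this assay compound 2 likewise gives only a limit, > 20000 nM. The step that the two limits leave unreadable from compound 1 to compound 2 therefore cannot be read, since both values sit at the limit (the limit of > 20000 nM in this assay, at which 3 of the 3 values shown sit). Compound 3 `O=C(c1ccc(-n2cc(-c3ccccc3)nn2)cc1O)N1CCCCC1` has the same atoms as compound 1, joined differently; the difference between the two cores is not broken down here. In this assay compound 3 also gives only a limit, > 20000 nM. Compound 4 `CCCCCc1ccc(-c2cn(-c3ccc(C(=O)N4CCCCC4)c(O)c3)nn2)cc1` is not yet measured and differs from compound 3 by the same change (pentyl in place of hydrogen on an aromatic carbon). Within the data shown here, because every value so far sits at the limit (the limit of > 20000 nM in this assay, at which 3 of the 3 values shown sit), compound 4 is expected to return a limit as well, with a step that the limit leaves unreadable from compound 3 to compound 4. The estimate for compound 4 is 30000 nM, lying between 10000 nM and 100000 nM.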

Compound 4, half-maximal inhibitory concentration: > 20000 nM
Compound 4: only a limit was reported (the forecaster's own chance of this, stated with the estimate: 85%); the middle value is on the limit's open side.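

Compound 3 and compound 4 both give only a limit, so no step can be read between them: the limit of > 20000 nM in this assay, at which 4 of the 4 values shown sit.

The compounds shown leave open whether pentyl in place of hydrogen changes inhibition at all in this assay, and whether the two cores differ.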